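This account rests on a few compounds, and the source may have more. Where it says the series, first, only, none or still open, it means among the compounds named here.

Compound 1 `COc1ccc(-c2nc(SCC(=O)c3sc(-c4ccccc4)nc3C)nc(N)c2C#N)cc1` was examined in a functional assay on U-87MG ATCC cells for antiproliferative activity against U-87 MG (Homo sapiens), read by MTT assay, with a stated time of 48 h, tested at 50 uM (a lower number here means a stronger effect, a higher number a weaker effect of the compound at the concentration tested), where compound 1 gives 33.8%. Among the three compounds for which numbers exist, compound 1 stands second highest. The nearest number belongs to compound 2 `COc1ccc(-c2nc(C)c(C(=O)CSc3nc(-c4ccc(OC)c(OC)c4)c(C#N)c(=O)[nH]3)s2)cc1`, which in this assay gives 22.2%, a number lower than that of compound 1 by more than the scatter. The furthest belongs to compound 3 `Cc1nc(-c2ccccc2)sc1C(=O)CSc1nc(-c2cccc(Cl)c2)c(C#N)c(=O)[nH]1`, which in this assay gives 50.6%, a number higher than that of compound 1 by more than the scatter. Compound 4 `Cc1nc(-c2ccccc2)sc1C(=O)CSc1nc(N)c(C#N)c(-c2ccccc2)n1` has not yet been measured. It differs from compound 1 in a single place: hydrogen in place of methoxy on an aromatic carbon. Going by the values given here, no pair of measured compounds differs by this change alone, so no measured step exists for it. The author expects the step of a number 6.2 percentage points higher from compound 1 to compound 4 (within the scatter) to be modest, pointing toward a higher number, and possibly not beyond the scatter at all. Compound 4 is therefore estimated at 40%, within a range from 24% to 58%.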

Compound 4, a percentage reported as activity, at one concentration (the size of the read-out at that concentration, not a potency): 26.3%
Beside the measured number, compound 4's estimate is 13.7 percentage points above it; the range from low to high includes it.
By their numbers in this assay, from the lowest: compounds 2, 4 and 1 (each within the scatter of the next, the first and the last beyond it); then compound 3.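

In this assay, going by these compounds alone, the first measured step for 4-methoxyphenyl to phenyl is a number 7.5 percentage points lower from compound 1 to compound 4 (within the scatter), so at this place, on an aromatic carbon para to a large group, compound 1 and compound 4 cannot be told apart. For this pair, the methoxy group is not needed for a read-out of this size at the one concentration tested. No measurement of any other kind bears on this result, so it stands without an explanation.

On these data alone, whether a hydroxyl group, an amine or a carboxylic acid at the same place would give a number beyond the scatter remains open. Also open is whether hydrogen in place of methoxy would give a similar step on the other compounds shown, which differ from compound 1 in more than one place.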